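Hydroxypyrrolidine in place of the carboxypiperidine arm

The source may hold more compounds than are shown below. What is called first, only, known or untested is meant among the compounds shown, and "the series" means these compounds.

Measured so far in a functional assay on HepG2 cells (Homo sapiens) for antiproliferative activity, read by CCK-8 assay, with a stated time of 48 h; a lower number here means a stronger inhibitor, a higher number a weaker inhibitor:
compound 1, `COc1ccc(/C=C\c2cc(OC)c(OC)c(OC)c2)cc1OCc1ccc(CNC(C)(C)C(=O)O)cc1`, gives 6500 nM
compound 2, `COc1ccc(/C=C\c2cc(OC)c(OC)c(OC)c2)cc1OCc1ccc(CN2CCCCC2C(=O)O)cc1`, gives 3100 nM
compound 3, `COc1ccc(/C=C\c2cc(OC)c(OC)c(OC)c2)cc1OCc1ccc(CNCCNC(C)=O)cc1`, gives 6100 nM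

Among these three numbers compound 2 has the lowest, yet only compound 1 is clearly set apart from it, by a 2.1-fold lower number from compound 1 to compound 2 (0.32 log units; beyond the scatter), while a 2.0-fold higher number from compound 2 to compound 3 (0.29 log units; within the scatter) stays within the scatter. Compound 4, `COc1ccc(/C=C\c2cc(OC)c(OC)c(OC)c2)cc1OCc1ccc(CN2CC[C@@H](O)C2)cc1`, differs from compound 2 as follows: 3-hydroxypyrrolidin-1-yl in place of 2-carboxypiperidin-1-yl on a saturated chain carbon bound to an aromatic carbon. For the measured compounds named here, no measured step makes exactly this exchange. The comparisons that bear on it, a 2.1-fold lower number from compound 1 to compound 2 (0.32 log units; beyond the scatter) and a 2.0-fold higher number from compound 2 to compound 3 (0.29 log units; within the scatter), show that changing the group at this position shifts the number only modestly in either direction. The step of a 1.1-fold lower number from compound 2 to compound 4 (0.04 log units; within the scatter) is therefore expected to be small, not clearly beyond the scatter. Compound 4 is estimated at 2800 nM, with a range from 800 nM to 9000 nM.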

Compound 4, half-maximal inhibitory concentration: 6200 nM
Compound 4: middle estimate off by 2.2-fold (0.35 log units), on the low side, and the stated range covers the measured number.
By their numbers in this assay, from the lowest: compounds 2, 3, 4 and 1 (each within the scatter of the next, the first and the last beyond it).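

In this assay, the step of a 2.0-fold higher number from compound 2 to compound 4 (0.30 log units; within the scatter) stays within the scatter, so on this saturated chain carbon the 3-hydroxypyrrolidin-1-yl arm cannot be told apart from the 2-carboxypiperidin-1-yl arm, even with no carboxylic acid present. The steps of a 1.0-fold higher number from compound 3 to compound 4 (0.01 log units; within the scatter) and a 1.0-fold lower number from compound 1 to compound 4 (0.02 log units; within the scatter) are also within the scatter, so compound 4 reads alike with all three earlier compounds. Nothing shown explains this. On these data alone, whether a morpholine or a plain piperidine at this place would give a number clearly apart from these remains open.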